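Thiourea aryl swap on the shared core

The compounds below may be only part of what the source reports. "The series", "measured", "known", "first", "only" and "open" are said of these compounds alone.

Compound 1 `NC(=O)c1c(NC(=O)c2ccccc2Cl)sc2c1CCNC2` in a functional assay on MKN-74 cells (Homo sapiens) for antiproliferative activity, with a stated time of 24 h (on this read-out lower numbers stand for stronger inhibition and higher numbers for weaker inhibition), gives 28700 nM. Compound 2 `NC(=O)c1c(NC(=O)c2ccccc2Cl)sc2c1CCN(Cc1cc(Cl)cc(Cl)c1)C2` gives 23700 nM, a step of a 1.2-fold lower number from compound 1 to compound 2 (0.08 log units; within the scatter). Compound 3 `NC(=O)c1c(NC(=O)c2ccccc2Cl)sc2c1CCN(C(=S)Nc1ccccc1-c1ccccc1)C2` gives 25800 nM and stands second highest of the three numbers, though within the scatter of both compound 2 and compound 1. Compound 4 `NC(=O)c1c(NC(=O)c2ccccc2Cl)sc2c1CCN(C(=S)Nc1cccnc1)C2` differs from compound 3 by pyridin-3-yl in place of 2-phenylphenyl on an amide-type nitrogen. Among the measured compounds shown here, no measured step touches the group on that amide-type nitrogen: the only measured step, from compound 1 to compound 2, sits on the ring amine nitrogen and was within the scatter, and all three numbers lie close together. For compound 4 the expected step is therefore a 1.0-fold lower number from compound 3 to compound 4 (0.01 log units; within the scatter), none beyond the scatter. Compound 4 is estimated at 25000 nM, with a range of 10000 nM to 60000 nM.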

Compound 4, half-maximal inhibitory concentration: 38600 nM
The estimate for compound 4 lay 1.5-fold (0.19 log units) below the measured number, within the range that was stated.
By their numbers in this assay, from the lowest: compounds 2, 3, 1 and 4 (each within the scatter of the next).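

In this assay, among the compounds shown here, the first change on the amide-type nitrogen, pyridin-3-yl in place of 2-phenylphenyl, gives a 1.5-fold higher number from compound 3 to compound 4 (0.17 log units; within the scatter) and so stays inside the scatter despite losing one aromatic ring and gaining a ring nitrogen. On the amine nitrogen in a ring, the group of compound 4 gives a 1.3-fold higher number from compound 1 to compound 4 (0.13 log units; within the scatter) against hydrogen and a 1.6-fold higher number from compound 2 to compound 4 (0.21 log units; within the scatter) against 3,5-dichlorobenzyl, so neither comparison separates these groups. No measurement at hand accounts for these steps. From the compounds shown here alone, whether a carboxylic acid or an amine on the pyridin-3-yl ring would give a step beyond the scatter remains open.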